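A hydroxymethylphenyl ring replaces bromophenyl on the core

The source may report more compounds than this note shows. Statements on the series, on what has been measured and on what is new or still open speak of the compounds shown alone.

Of the compounds shown here, two share a core and have been tested in a functional assay on the whole organism (strain Wistar) for inhibition, with Rattus norvegicus as the target, read by paw edema, with stated times of 30 min and 3 h, at a dose of 0.05 mmol/kg by the oral route; on this read-out higher numbers stand for more inhibition at the one dose given (going by the name of the read-out) and lower numbers for less inhibition. Compound 1 `CS(=O)(=O)c1ccc(N2N=C(c3ccccc3)CCC2=O)cc1` gives 26.6%. For the measured compounds named here, compound 2 `CS(=O)(=O)c1ccc(N2N=C(c3ccc(Br)cc3)CCC2=O)cc1` gives 10%, the lower of the two numbers, and its only neighbour is compound 1. Going by the values given here, the one measured step, a number 16.6 percentage points lower from compound 1 to compound 2 (beyond the scatter), shows that changing the aromatic ring on the carbon with a double bond to nitrogen can move the read-out beyond the scatter.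

Compound 3 `Cc1ccc(O)c(C2=NN(c3ccc(S(C)(=O)=O)cc3)C(=O)CC2)c1` carries a different ring there: 2-hydroxy-5-methylphenyl in place of 4-bromophenyl on a carbon with a double bond to nitrogen. Among the compounds with values here, this removes the bromine whose arrival lowered the number, but hydroxy and methyl groups at this ring have no measured precedent, so the direction rests on compound 1 alone. A rise back toward compound 1 is expected, a number 12 percentage points higher from compound 2 to compound 3 (beyond the scatter), with wide uncertainty. Compound 3 is therefore estimated to give 22%, between 8% and 38%.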

Compound 3, a percentage reported as inhibition, in the whole organism at one dose (the size of the read-out at that dose, not a potency): 66.6%
Estimate against measurement, compound 3: 44.6 percentage points below; measured number above the stated range.
By their numbers in this assay, from the lowest: compound 2; then compound 1; then compound 3.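

In this assay this position proves able to raise the number as well as lower it: 2-hydroxy-5-methylphenyl in place of 4-bromophenyl gives a number 56.6 percentage points higher from compound 2 to compound 3 (beyond the scatter) and the same ring in place of plain phenyl gives a number 40 percentage points higher from compound 1 to compound 3 (beyond the scatter) on the same core. The second step shows that losing the bromine does not account for the whole gain, since compound 3 also stands well clear of compound 1, which has no bromine. Nothing available here explains the rise.

Going by these compounds, the hydroxy and methyl groups enter together, so the share of each stays open. Also open, on these data alone, is whether a ring carrying only one of them, or a methoxy or amino group in place of the hydroxy, would keep the number this high.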